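From ureido to piperazin-1-yl on the shared core

A few compounds are considered here, and "the series" means these few. Any claim that something is new, unique, unknown or untested is made for them only; others in the source may bear on it.

In a functional assay on GOTO cells (Homo sapiens) for cytotoxicity, read by MTT assay, with a stated time of 3 days (a higher number here means a weaker inhibitor, a lower number a stronger inhibitor), compound 1 (`N#Cc1c(NN)nc(SCc2nc3ccccc3[nH]2)nc1-c1ccccc1`) gives 2.68 nM, compound 2 (`N#Cc1c(Nc2ccccn2)nc(SCc2nc3ccccc3[nH]2)nc1-c1ccccc1`) gives 2.5 nM and compound 3 (`N#Cc1c(NC(N)=O)nc(SCc2nc3ccccc3[nH]2)nc1-c1ccccc1`) gives 11.3 nM, the highest number of the three. Compound 4 (`N#Cc1c(-c2ccccc2)nc(SCc2nc3ccccc3[nH]2)nc1N1CCNCC1`) carries piperazin-1-yl in place of ureido on an aromatic carbon. Two measured steps show ureido-bearing compound 3 apart from its neighbours: a 4.2-fold higher number from compound 1 to compound 3 (0.62 log units; beyond the scatter) and a 4.5-fold higher number from compound 2 to compound 3 (0.66 log units; beyond the scatter). The remaining step, a 1.1-fold lower number from compound 1 to compound 2 (0.03 log units; within the scatter), shows that two quite different replacements for the carbamoyl give similar values. Within the data shown here, no measured compound carries piperazin-1-yl, so the comparison is indirect. A modest move to a lower number is expected, namely a 2.3-fold lower number from compound 3 to compound 4 (0.35 log units; beyond the scatter). Compound 4 is estimated at 5 nM, with an expected range of 1.5 nM to 20 nM.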

Compound 4, half-maximal inhibitory concentration: 3.7 nM
Estimate against measurement, compound 4: 1.4-fold (0.13 log units) above, and the stated range covers the measured number.
By their numbers in this assay, from the lowest: compounds 2, 1 and 4 (each within the scatter of the next); then compound 3.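

At this aromatic carbon a six-membered non-aromatic ring is accepted in place of ureido, with a 3.1-fold lower number from compound 3 to compound 4 (0.48 log units; beyond the scatter) in this assay, while a 1.5-fold higher number from compound 2 to compound 4 (0.17 log units; within the scatter) and a 1.4-fold higher number from compound 1 to compound 4 (0.14 log units; within the scatter) show no separation from the two other groups joined through nitrogen. Among these four compounds only compound 3 stands apart, so the position accommodates groups as different as aminoamino, (pyridin-2-yl)amino and piperazin-1-yl. No evidence is available to explain this result. The compounds shown leave open whether the second ring nitrogen of piperazin-1-yl matters, which morpholin-4-yl or 4-methylpiperazin-1-yl at this carbon would test, and whether an open-chain amine would match the ring.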